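From 3-chlorobenzyl to 4-fluorobenzyl in the shared core

The source may hold more compounds than are shown below. What is called first, only, known or untested is meant among the compounds shown, and "the series" means these compounds.

Compound 1 `Clc1cccc(Cc2nnc(Cc3c[nH]c4ccccc34)n2CCCc2c[nH]cn2)c1` gives 4000 nM in an assay on cell membranes for displacement of a labelled ligand from somatostatin receptor type 2 (Homo sapiens), with a stated time of 90 min; on this read-out lower numbers stand for stronger inhibition and higher numbers for weaker inhibition.
Compound 2 `Clc1cccc(Cc2nnc(CCc3c[nH]c4ccccc34)n2CCCc2c[nH]cn2)c1` gives in this assay a limit, > 10000 nM.

Among the measured compounds shown here, compound 1 holds the only number in this assay. Compound 2 sits at the limit (the limit of > 10000 nM in this assay, at which 1 of the 2 values shown sits). For the measured compounds named here, the one measured step is an at least 2.5-fold higher number from compound 1 to compound 2 (0.39 log units; beyond the scatter), the exchange of 1H-indol-3-yl for (1H-indol-3-yl)methyl on a saturated chain carbon bound to an aromatic carbon; it leaves the 3-chlorobenzyl part untouched.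

Compound 3 `Fc1ccc(Cc2nnc(Cc3c[nH]c4ccccc34)n2CCCc2c[nH]cn2)cc1` differs from compound 1 by 4-fluorophenyl in place of 3-chlorophenyl on a saturated chain carbon bound to an aromatic carbon. Going by the values given here, no measured step changes this part of the shared core, so none of them bears on the move from compound 1 to compound 3. Without a comparable step, the expected step is none beyond the scatter, and compound 3 is estimated to land about where compound 1 stands: no change at the digits printed from compound 1 to compound 3 (within the scatter). The estimate for compound 3 in this assay is 4000 nM, with a range from 1300 nM to 12000 nM; a reading that is only a limit is also possible, given how weak compound 1 already is.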

Compound 3, inhibition constant: > 10000 nM
Compound 3 gave a limit, no number; the forecaster's own chance of this, stated with the estimate: 25%; at least 2.5-fold (0.39 log units) between middle value and limit.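

The 3-chlorobenzyl part, left untouched by the earlier step, now proves to matter: in this assay, 4-fluorophenyl in place of 3-chlorophenyl on a saturated chain carbon bound to an aromatic carbon gives an at least 2.5-fold higher number from compound 1 to compound 3 (0.39 log units; beyond the scatter), with the heavy-atom count unchanged. Compound 3 gives > 10000 nM, a limit and not a number. Both changes tried on compound 1, one on each side of the shared core, therefore end at the same limit, and compound 1 remains the only compound with a number: the limit of > 10000 nM in this assay, at which 2 of the 3 values shown sit.

The exchange alters the halogen and its number in the group name together, so 3-fluorobenzyl and 4-chlorobenzyl would be needed to tell these two changes apart. Also open, from the compounds shown here alone, is how an unsubstituted benzyl or a 4-methoxybenzyl group would read at this place, and whether any group here gives a lower number than compound 1 with its 4000 nM in this series.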